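A Pyridin-2-yl Replaces Methyl on the Shared Core

The source may report more compounds than this note shows. Statements on the series, on what has been measured and on what is new or still open speak of the compounds shown alone.

Three measured compounds share one core, a ketone joined through a chain to a phenyl ring, and differ only in the group on one aromatic carbon of the five-membered ring. Compound 1 `COc1coc(C(=O)CCCCCCc2ccccc2)n1` carries a methoxy group there, and in an assay on HEK-293T cells for inhibition of diacylglycerol lipase-alpha (Homo sapiens), read by colorimetric assay (on this read-out lower numbers stand for stronger inhibition and higher numbers for weaker inhibition), compound 1 gives only a limit, > 10000 nM. Compound 2 `O=C(CCCCCCc1ccccc1)c1nc(Br)co1` carries a bromo group; in this assay compound 2 likewise gives only a limit, > 10000 nM. Compound 3 `Cc1coc(C(=O)CCCCCCc2ccccc2)n1` carries a methyl group; in this assay compound 3 also gives only a limit, > 10000 nM. The steps a step that the two limits leave unreadable from compound 1 to compound 2, a step that the two limits leave unreadable from compound 1 to compound 3 and a step that the two limits leave unreadable from compound 2 to compound 3 therefore carry no readable size, since the limit of > 10000 nM in this assay, at which 3 of the 3 values shown sit, holds all three values. Compound 3 thus stands at that limit, with no number of its own.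

Compound 4 `O=C(CCCCCCc1ccccc1)c1nc(-c2ccccn2)co1` differs from compound 3 by pyridin-2-yl in place of methyl on an aromatic carbon. All three measured steps concern this same aromatic carbon, yet none gives a size or a direction, so they offer no guide beyond showing that small groups there leave inhibition weak. The pyridin-2-yl is a far larger group than any tried. Compound 4 is estimated at 1000 nM, within 100 nM to 10000 nM. The expected step of an at least 10-fold lower number from compound 3 to compound 4 (1.00 log units; beyond the scatter) is uncertain in size and may again end at a limit.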

Compound 4, half-maximal inhibitory concentration: > 10000 nM
Compound 4 gave a limit, no number (the forecaster's own chance of this, stated with the estimate: 40%); middle value at least 10-fold (1.00 log units) from the limit.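

Compound 4 gives only a limit in this assay, so no step among compound 1, compound 2, compound 3 and compound 4 can be read, since all four sit at one limit: the limit of > 10000 nM in this assay, at which 4 of the 4 values shown sit.

The compounds shown leave open whether any group on this aromatic carbon gives a measurable inhibition.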